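Trading difluorophenyl for methylphenyl on the sulfonyl group

The compounds below may be only part of what the source reports. "The series", "measured", "known", "first", "only" and "open" are said of these compounds alone.

In an ADME assay on microsomes from liver (Mus musculus) for metabolic stability, read by LC-MS, with a stated time of 30 min, tested at 1 uM (a lower number here means that less of the compound is left, a higher number that more of the compound is left), compound 1 `Cc1ccccc1S(=O)(=O)c1ccc(CNC(=O)c2cc3cnccc3[nH]2)cc1` gives 15% and compound 2 `O=C(NCc1ccc(S(=O)(=O)c2ccc(F)c(F)c2)cc1)c1cc2cnccc2[nH]1` gives 58% as the higher of the two numbers. Compound 3 `Cc1cccc(S(=O)(=O)c2ccc(CNC(=O)c3cc4cnccc4[nH]3)cc2)c1` carries 3-methylphenyl in place of 3,4-difluorophenyl on a sulfonyl sulfur. For the measured compounds named here, one measured step bears on this: a number 43 percentage points higher from compound 1 to compound 2 (beyond the scatter) with 3,4-difluorophenyl in place of 2-methylphenyl, a large step. Like compound 1 at 15% compound 3 carries a methylphenyl, so most of that gain is expected to vanish. In this assay the expected step is a number 31 percentage points lower from compound 2 to compound 3 (beyond the scatter) and thus a large fall. Compound 3 is estimated at 27% (range 12% to 45%).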

Compound 3, percent of the compound remaining: 32%
Beside the measured number, compound 3's estimate is 5 percentage points below it; the measured number falls inside the stated range.
By their numbers in this assay, from the lowest: compound 1; then compound 3; then compound 2.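

In this assay a change from 2-methylphenyl to 3-methylphenyl gives a number 17 percentage points higher from compound 1 to compound 3 (beyond the scatter) on the same sulfonyl sulfur, so these two methylphenyl groups do not count as equal here. The change from 3,4-difluorophenyl to 3-methylphenyl still gives a number 26 percentage points lower from compound 2 to compound 3 (beyond the scatter) at this place, which keeps the difluorophenyl compound on top among these three. No measurement shown here explains either step. Going by these compounds, how a plain phenyl, a 4-fluorophenyl or a 4-methoxyphenyl on this sulfur would compare remains open, and so does how much each fluorine contributes alone.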